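A few compounds are considered here, and "the series" means these few. Any claim that something is new, unique, unknown or untested is made for them only; others in the source may bear on it.

The three compounds measured so far:

compound 1, `COc1ccc(S(=O)(=O)c2cnc3c(F)cccc3c2-c2cccc(Cl)c2)cc1`, 2.75 mL/min
compound 2, `COc1cccc(-c2c(S(=O)(=O)c3cc(Cl)cc(Cl)c3)cnc3cc(F)ccc23)c1`, 1.51 mL/min
compound 3, `COc1ccc(S(=O)(=O)c2cnc3c(F)cccc3c2-c2cccc(OC)c2)cc1`, 2.87 mL/min

All three numbers come from an ADME assay on microsomes from liver (Homo sapiens) for metabolic stability, tested at 2.5 uM; on this read-out higher numbers stand for fast clearance and lower numbers for slow clearance. Compound 4, `O=S(=O)(c1cc(Cl)cc(Cl)c1)c1cnc2cc(F)ccc2c1-c1cccc(Cl)c1`, has not yet been run in this assay. It differs from compound 2 in one place: chloro in place of methoxy on an aromatic carbon. Exactly the same swap separates compound 3 from compound 1: chloro in place of methoxy on an aromatic carbon. That pair gives a feel for what the swap does: a 1.0-fold lower number from compound 3 to compound 1 (0.02 log units; within the scatter). In other words, exchanging methoxy for chloro at that spot left the clearance essentially unchanged. The cores of compound 2 and compound 3 are not identical, but the difference between the two cores is not broken down here. Since the place of the swap is described in identical words for both pairs, the change made to compound 2 is the same change. The step from compound 2 to compound 4 is therefore expected to be just as flat, a 1.0-fold higher number from compound 2 to compound 4 (0.01 log units; within the scatter), an expectation resting on a 1.0-fold lower number from compound 3 to compound 1 (0.02 log units; within the scatter). Compound 4 is accordingly estimated at 1.55 mL/min in this assay, most likely between 0.9 mL/min and 2.8 mL/min.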

Compound 4, intrinsic clearance in a liver preparation (reported as CLH), per the amount of preparation that the assay uses: 0.93 mL/min
Beside the measured number, compound 4's estimate is 1.7-fold (0.22 log units) above it; measured number inside the range.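

In this assay, the move from 3-methoxyphenyl to 3-chlorophenyl gives a 1.6-fold lower number from compound 2 to compound 4 (0.21 log units; within the scatter), and this new step can be set directly beside the earlier one: the same change on two cores in this assay, a 1.0-fold lower number (0.02 log units; within the scatter) from compound 3 to compound 1 and a 1.6-fold lower number (0.21 log units; within the scatter) from compound 2 to compound 4, 1.6-fold (0.19 log units) apart, within the scatter of two such steps. For these two cores, then, the change carries over in the simplest sense: neither step stands clear of the usual scatter, and the two steps do not differ from each other by more than that scatter. This does not show that the swap would be just as quiet on every core in the series, since two pairs are a small sample, and it says nothing about why clearance responds so little.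

The compounds shown compare only methoxy and chloro at this place on the aromatic ring. Whether a very different group there, such as an amine or a carboxylic acid, would leave clearance just as flat remains an open question.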